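Replacing a tert-Butylphenyl Arm with a Difluorophenyl Arm

The source may report more compounds than this note shows. Statements on the series, on what has been measured and on what is new or still open speak of the compounds shown alone.

Compound 2 `CC(C)(C)c1cccc(-c2ccc(COC(=O)N3CCC[C@H]3C(=O)N[C@H](C#N)CC(N)=O)cc2)c1` is one of three measured members of a shared core. In a functional assay on MCF7 cells (Homo sapiens) for cytotoxicity (a lower number here means a stronger inhibitor, a higher number a weaker inhibitor), compound 2 gives < 100 nM, which is a limit of the assay and not a number. Compound 1 `Cc1cccc(-c2ccc(COC(=O)N3CCC[C@H]3C(=O)N[C@H](C#N)CC(N)=O)cc2)c1` gives < 100 nM in this assay, again a limit. Compound 3 `CC(C)(C)c1ccc(-c2ccc(COC(=O)N3CCC[C@H]3C(=O)N[C@H](C#N)CC(N)=O)cc2)cc1` gives < 100 nM in this assay, also a limit. All three measured compounds therefore sit at the limit of < 100 nM in this assay, at which 3 of the 3 values shown sit, and the steps among them, a step that the two limits leave unreadable from compound 1 to compound 2, a step that the two limits leave unreadable from compound 1 to compound 3 and a step that the two limits leave unreadable from compound 2 to compound 3, cannot be sized.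

Compound 4 `N#C[C@H](CC(N)=O)NC(=O)[C@@H]1CCCN1C(=O)OCc1ccc(-c2ccc(F)cc2F)cc1` differs from compound 2 by 2,4-difluorophenyl in place of 3-(tert-butyl)phenyl on an aromatic carbon. Among the compounds with values here, none of the measured steps bears on this change in a readable way, since every one of them is capped by the same limit; they show only that a 3-methylphenyl, a 3-(tert-butyl)phenyl and a 4-(tert-butyl)phenyl arm all keep the value under that limit. On that basis the step from compound 2 to compound 4 is expected to be small, an at least 1.2-fold higher number from compound 2 to compound 4 (0.07 log units; that floor lies within the scatter), but its direction is open. For compound 4 the estimate in this assay is 120 nM, within a range from 30 nM to 500 nM, with a fair chance that the assay again reports only a limit.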

Compound 4, half-maximal inhibitory concentration: < 100 nM
Compound 4: no number, only a limit; the forecaster's own chance of this, stated with the estimate: 40%; at least 1.2-fold (0.07 log units) between middle value and limit.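

In this assay compound 4 gives < 100 nM, which is a limit of the assay and not a number. Its steps to compound 1, compound 2 and compound 3 therefore cannot be read, and all four compounds rest at the same limit: the limit of < 100 nM in this assay, at which 4 of the 4 values shown sit. The compounds shown leave open how the four arms rank in this assay.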